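The source may hold more compounds than are shown below. What is called first, only, known or untested is meant among the compounds shown, and "the series" means these compounds.

Measured compounds in an assay on isolated protein for inhibition of protein kinase C delta type (Homo sapiens), read by TR-FRET, with a stated time of 2 h; on this read-out lower numbers stand for stronger inhibition and higher numbers for weaker inhibition:
compound 1 `CC1(C)C[C@H](Nc2cc(NCc3cnccc3C(F)(F)F)ncc2C#N)CC[C@H]1O` gives 2200 nM
compound 2 `CC1(C)C[C@@H](Nc2cc(NCc3cnccc3C(F)(F)F)ncc2C#N)CC[C@@H]1O` gives 2400 nM

Among the compounds with values here, compound 2 holds the higher of the two numbers, with compound 1 as its only neighbour, and the two values lie within the scatter of each other. Within the data shown here, the single measured step is a 1.1-fold higher number from compound 1 to compound 2 (0.04 log units; within the scatter), which is within the scatter and fits with the fact that compounds 1 and 2 differ only in the configuration as drawn.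

Compound 3 `CC1(C)[C@H](Nc2cc(NCc3cnccc3C(F)(F)F)ncc2C#N)C[C@H]1C(N)=O` has not yet been measured. It differs from compound 2 by 3-carbamoyl-2,2-dimethylcyclobutyl in place of 4-hydroxy-3,3-dimethylcyclohexyl on a nitrogen on an aromatic ring. The shared core is unchanged; the change concerns only the ring on that nitrogen and the group it carries.

Among the measured compounds shown here, no measured step bears on this change. For the measured compounds named here, the only step available, the one from compound 1 to compound 2, concerns configuration alone and is within the scatter, so it says nothing about the size or direction of a change of ring or substituent. The expectation for this assay is therefore a step near zero with a wide range. Compound 3 is expected to give 2500 nM, with a range from 500 nM to 12000 nM. The estimated step is a 1.0-fold higher number from compound 2 to compound 3 (0.02 log units; within the scatter).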

Compound 3, half-maximal inhibitory concentration: 900 nM
Compound 3: the middle estimate sits 2.8-fold (0.44 log units) above what was measured; measured number inside the range.
By their numbers in this assay, from the lowest: compound 3; then compounds 1 and 2 (each within the scatter of the next).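

In this assay, the substituent on the nitrogen on an aromatic ring now shows that a change of ring and carried group can move the number, which the earlier pair, differing in configuration alone, could not show: the result is a 2.7-fold lower number from compound 2 to compound 3 (0.43 log units; beyond the scatter), and against the other cyclohexyl compound it is a 2.4-fold lower number from compound 1 to compound 3 (0.39 log units; beyond the scatter). The lower number comes with no change in the counted heavy atoms, hydrogen-bond donors or hydrogen-bond acceptors of the substituent, so in this one comparison those counts do not track the difference. The two steps read alike because the two cyclohexyl starting points are so close: the fact that compounds 1 and 2 differ only in the configuration as drawn

Ring size and carried group change together here, so it stays open whether the step belongs to the four-membered ring, to the carbamoyl group or to both, and what the configuration of compound 3 contributes. A four-membered ring carrying hydroxy, a six-membered ring carrying carbamoyl, and a carboxylic acid or an amine in place of the carbamoyl group are the comparisons that bear on this.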